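A Piperidinyl Oxetane Replaces the Trifluoromethylphenyl Sulfone

The compounds below may be only part of what the source reports. "The series", "measured", "known", "first", "only" and "open" are said of these compounds alone.

Of the compounds shown here, three have been measured in an assay on isolated protein for inhibition of Nicotinamide phosphoribosyltransferase (Homo sapiens), read by mass spectrometry, with stated times of 15 min and 30 min; a lower number here means a stronger inhibitor, a higher number a weaker inhibitor. Compound 1 `O=C(NCc1ccc(S(=O)(=O)c2ccccc2)cc1)N1Cc2cccnc2C1` gives 60 nM. Compound 2 `O=S(=O)(c1ccccc1)c1ccc(CNS(=O)(=O)N2Cc3ccncc3C2)cc1` reaches only a limit of the assay, > 2000 nM. Compound 3 `O=C(NCc1ccc(S(=O)(=O)c2cccc(C(F)(F)F)c2)cc1)N1Cc2ccncc2C1` gives 8 nM, the lowest of the two numbers, and the nearest number, that of compound 1, sits higher by a margin beyond the usual scatter. Compound 4 `O=C(NCc1ccc(S(=O)(=O)C2CCN(C3COC3)CC2)cc1)N1Cc2ccncc2C1` has not yet been measured. It differs from compound 3 in one place: 1-(oxetan-3-yl)piperidin-4-yl in place of 3-(trifluoromethyl)phenyl on a sulfonyl sulfur. For the measured compounds named here, with no step between measured compounds to lean on, one expects a moderate shift toward a weaker inhibitor, a 5.0-fold higher number from compound 3 to compound 4 (0.70 log units; beyond the scatter). Compound 4 is therefore estimated at 40 nM in this assay, expected to fall between 10 nM and 200 nM.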

Compound 4, half-maximal inhibitory concentration: 31 nM
The estimate for compound 4 lay 1.3-fold (0.11 log units) above the measured number; the measured number falls inside the stated range.
By their numbers in this assay, from the lowest: compound 3; then compounds 4 and 1 (each within the scatter of the next). At a limit, above all of these: compound 2.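

Until now the sulfonyl sulfur had carried only aromatic rings; compound 4 shows that a saturated group can stand there. In this assay, 1-(oxetan-3-yl)piperidin-4-yl in place of 3-(trifluoromethyl)phenyl gives a 3.9-fold higher number from compound 3 to compound 4 (0.59 log units; beyond the scatter), so this change costs only modestly, leaving compound 4 at 31 nM. No measurement shown bears on what lies behind this step. The compounds shown leave open how much of this number rests on the oxetane and how much on the piperidine. A free piperidine amine or a plain cyclohexyl ring on the sulfonyl sulfur would separate the two.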